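Cyclic amine replacement on the shared core: compound 4

The source may report more compounds than this note shows. Statements on the series, on what has been measured and on what is new or still open speak of the compounds shown alone.

Measured in a functional assay on A549 cells (Homo sapiens) for inhibition, read by MTT assay, with a stated time of 72 h; a higher number here means a weaker inhibitor, a lower number a stronger inhibitor:
compound 1 `CNC(=O)c1cc(Oc2ccc(Nc3nccc(N4CCCC4)n3)cc2)ccn1`: 3410 nM
compound 2 `CN(c1ccc(Oc2ncnc3ccsc23)cc1)c1nccc(N2CCCC2)n1`: 6510 nM
compound 3 `CN(c1ccc(Oc2ncnc3ccsc23)cc1)c1nccc(N2CCc3ccccc3C2)n1`: 16200 nM

Compound 3 gives the highest of the three numbers; compound 2 is nearest and compound 1 furthest, both separations beyond the scatter. Compound 4 `CN(c1ccc(Oc2ncnc3ccsc23)cc1)c1nccc(N2CCCCC2)n1` is not yet measured. It differs from compound 3 in one place: piperidin-1-yl in place of 1,2,3,4-tetrahydroisoquinolin-2-yl on an aromatic carbon. Going by the values given here, the one measured step that bears on this is the exchange of pyrrolidin-1-yl for 1,2,3,4-tetrahydroisoquinolin-2-yl on an aromatic carbon, a 2.5-fold higher number from compound 2 to compound 3 (0.40 log units; beyond the scatter). Compound 4 carries piperidin-1-yl, one six-membered non-aromatic ring without the aromatic ring of carbon only, so a modest move back in this assay is expected, a 2.0-fold lower number from compound 3 to compound 4 (0.31 log units; beyond the scatter). For compound 4 the estimate is 8000 nM, with a range from 3500 nM to 18000 nM.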

Compound 4, half-maximal inhibitory concentration: 8240 nM
Compound 4: middle estimate off by 1.0-fold (0.01 log units), on the low side, within the range that was stated.
By their numbers in this assay, from the lowest: compounds 1, 2, 4 and 3 (each within the scatter of the next, the first and the last beyond it).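

In this assay, piperidin-1-yl on this aromatic carbon is not separated from either neighbour: a 2.0-fold lower number from compound 3 to compound 4 (0.29 log units; within the scatter) and a 1.3-fold higher number from compound 2 to compound 4 (0.10 log units; within the scatter) both lie within the scatter. Of the three cyclic amines, only pyrrolidin-1-yl and 1,2,3,4-tetrahydroisoquinolin-2-yl are separated from each other, so the six-membered non-aromatic ring alone gives no distinct reading here. No supporting data explain these readings. Still open, as far as these compounds go, is whether a ring with a second hetero atom, such as morpholine or piperazine, or an open-chain amine such as dimethylamino, would separate from these three.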